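The compounds below may be only part of what the source reports. "The series", "measured", "known", "first", "only" and "open" are said of these compounds alone.

This set follows what happens to a physicochemical assay for solubility, in phosphate buffer, measured as thermodynamic solubility, at pH 7.4 (on this read-out higher numbers stand for higher solubility and lower numbers for lower solubility), when the end of a short chain on a shared core is changed. Compound 1 `CS(=O)(=O)NC(=O)CCc1cn(-c2ccccc2Br)nc1-c1ccc(Cl)cc1` gives 165000 nM in this assay. Compound 2 `CS(=O)(=O)NC(=O)CCc1cn(-c2ccc(Br)cc2)nc1-c1ccccc1` gives 200000 nM in this assay. Compound 3 `CNC(=O)CCc1cn(-c2ccc(Br)cc2)nc1-c1ccc(Cl)cc1` ends its chain in a methylcarbamoyl group, and in this assay compound 3 returns only a limit, < 5000 nM, so no number is known for it. On the values shown, compound 3 therefore stands at the bottom edge of what was measured: the limit of < 5000 nM in this assay, at which 1 of the 3 values shown sits. No two of the measured compounds differ in just one place, so no single change has yet been followed from one number to another.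

Compound 4 `O=c1[nH]nc(CCc2cn(-c3ccc(Br)cc3)nc2-c2ccc(Cl)cc2)o1` has not been measured. It differs from compound 3 by a group of 6 heavy atoms (2 carbon, 2 nitrogen, 2 oxygen; one five-membered aromatic ring with 3 hetero atoms) in place of a group of 4 heavy atoms (2 carbon, 1 nitrogen, 1 oxygen; no ring), on a saturated chain carbon, two bonds along the chain from an aromatic carbon.

Because compound 3 sits at the limit < 5000 nM rather than at a number, any step from it can only be judged from that limit upward. The step of an at least 6.0-fold higher number from compound 3 to compound 4 (0.77 log units; beyond the scatter) is expected to be an increase in this assay beyond the usual scatter, with wide uncertainty. Compound 4 is expected to give about 30000 nM in this assay, within a range from 5000 nM to 150000 nM.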

Compound 4, solubility: < 5000 nM
Compound 4 was reported as a limit (the forecaster's own chance of this, stated with the estimate: 20%); at least 6.0-fold (0.77 log units) between middle value and limit.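

Among the compounds shown here, compound 3 and compound 4 each return only a limit in this assay, so no step between them can be read. The bottom edge of the values now holds both compounds: the limit of < 5000 nM in this assay, at which 2 of the 4 values shown sit.

As far as these compounds go, what stays open is the actual number for each of these two compounds, and so whether replacing methylcarbamoyl with the five-membered aromatic ring changes the read-out at all.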